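From 3,4-dimethoxyphenyl to phenyl in compound 3

A few compounds are considered here, and "the series" means these few. Any claim that something is new, unique, unknown or untested is made for them only; others in the source may bear on it.

In a functional assay on L1210 cells (Mus musculus) for antiproliferative activity, read by cell counting, with a stated time of 96 h (on this read-out lower numbers stand for stronger inhibition and higher numbers for weaker inhibition), compound 1 `COc1ccc(Oc2ccccc2NC(C)=C2C(=O)CC(c3ccccc3)CC2=O)cc1` gives 140 nM, while compound 2 `COc1ccc(Oc2ccccc2NC(C)=C2C(=O)CC(c3ccccc3)CC2=O)cc1OC` gives 65 nM, the lower of the two numbers. Compound 3 `CC(Nc1ccccc1Oc1ccccc1)=C1C(=O)CC(c2ccccc2)CC1=O` is still unmeasured. It differs from compound 2 by phenyl in place of 3,4-dimethoxyphenyl on an oxygen on an aromatic ring, with phenyl in place of 3,4-dimethoxyphenyl on an oxygen on an aromatic ring. Among the measured compounds shown here, the only step that bears on this is the modest 2.2-fold lower number from compound 1 to compound 2 (0.33 log units; beyond the scatter), seen when methoxy replaces hydrogen on an aromatic carbon. Losing both methoxy groups is thus expected to give a moderately higher number, an estimated 3.4-fold higher number from compound 2 to compound 3 (0.53 log units; beyond the scatter). For compound 3 the estimated value is 220 nM, with an expected range of 90 nM to 500 nM.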

Compound 3, half-maximal inhibitory concentration: 86 nM
Estimate against measurement, compound 3: 2.6-fold (0.41 log units) above, and the stated range ends above it.
By their numbers in this assay, from the lowest: compounds 2, 3 and 1 (each within the scatter of the next, the first and the last beyond it).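

In this assay the change from 3,4-dimethoxyphenoxy to phenoxy is a 1.3-fold higher number from compound 2 to compound 3 (0.12 log units; within the scatter) and the loss of the single methoxy is a 1.6-fold lower number from compound 1 to compound 3 (0.21 log units; within the scatter) so a plain phenyl on this oxygen stands level with each methoxy-bearing compound. Methoxy on this ring is therefore not needed for activity at this level. The only separation among the three remains a 2.2-fold lower number from compound 1 to compound 2 (0.33 log units; beyond the scatter) which is small.

From the compounds shown here alone, whether an amine, a carboxylic acid or a chlorine on this ring would shift the number stays open. No measurement shown here accounts for these results.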